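The source may report more compounds than this note shows. Statements on the series, on what has been measured and on what is new or still open speak of the compounds shown alone.

Compound 1 `CC(=O)Nc1cccc(C2CCN(CCn3c(-c4ccccc4)nc4ccccc43)CC2)c1`: 10000 nM
Compound 2 `COc1ccc(-c2nc3ccccc3n2CCCN2CCC(c3cccc(NC(C)=O)c3)CC2)cc1`: 9 nM

In an assay for displacement of a labelled ligand from melanin-concentrating hormone receptor 1 (Homo sapiens), read by fluorescence (on this read-out lower numbers stand for stronger inhibition and higher numbers for weaker inhibition), compound 2 gives 9 nM, the lowest of the two numbers; compound 1 gives 10000 nM, a gap well beyond the scatter, though the two compounds differ in more than one place. Compound 3 `CC(=O)Nc1cccc(C2CCN(CCCn3c(-c4ccc(Cl)c(Cl)c4)nc4ccccc43)CC2)c1` keeps the core of compound 2 and has 3,4-dichlorophenyl in place of 4-methoxyphenyl on an aromatic carbon. For the measured compounds named here, no measured pair isolates this change, so the expected step of a 2.2-fold higher number from compound 2 to compound 3 (0.35 log units; beyond the scatter) is a small shift toward a higher number, possibly none beyond the scatter. Compound 3 is estimated to give 20 nM, within a range from 5 nM to 80 nM.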

Compound 3, half-maximal inhibitory concentration: 24 nM
Compound 3: the middle estimate sits 1.2-fold (0.08 log units) below what was measured; the range from low to high includes it.
By their numbers in this assay, from the lowest: compound 2; then compound 3; then compound 1.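

Placing 3,4-dichlorophenyl instead of 4-methoxyphenyl on the aromatic carbon between two ring nitrogen atoms gives a 2.7-fold higher number from compound 2 to compound 3 (0.43 log units; beyond the scatter) in this assay and is the first comparison here that isolates a single change. The position therefore accepts a ring without the methoxy oxygen and with two chlorines, at a modest cost. Nothing available gives a reason for this step. Still open, from the compounds shown here alone, is how a 4-chlorophenyl or a pyridine ring would behave at this position, and so whether either chlorine matters on its own.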